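This account rests on a few compounds, and the source may have more. Where it says the series, first, only, none or still open, it means among the compounds named here.

Compound 1, `N=C(N)c1cccc(C(=O)N[C@@H](C(=O)N2CCC(Cc3ccccc3)CC2)c2ccccc2)c1`, gives 650 nM in an assay on isolated protein for binding affinity to serine protease 1 (Homo sapiens); a higher number here means a weaker inhibitor, a lower number a stronger inhibitor.
Compound 2, `CSCC[C@@H](NC(=O)c1cccc(C(=N)N)c1)C(=O)NCC1CCC(CN)CC1`, gives 10000 nM in this assay.
Compound 3, `N=C(N)c1cccc(C(=O)NC(C(=O)NCC2CCC(CN)CC2)c2cccc(Cl)c2)c1`, gives 5100 nM; 3900 nM (2 entries) in this assay; compound 3 was measured more than once: the several entries of compound 3 in this assay, 5100 nM; 3900 nM (2 entries).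

Of the two compounds with a single number, compound 2 stands highest; its nearest neighbour is compound 1, whose lower number lies beyond the usual scatter. For the measured compounds named here, no two measured compounds differ in only one place, so no measured step is available. Compound 4, `CC(C)[C@@H](NC(=O)c1cccc(C(=N)N)c1)C(=O)NCC1CCC(CN)CC1`, differs from compound 2 in one place: isopropyl in place of 2-(methylsulfanyl)ethyl on a saturated chain carbon bound to an amide-type nitrogen and a carbonyl carbon. On the numbers shown, the expected step from compound 2 to compound 4 in this assay is a 1.3-fold lower number from compound 2 to compound 4 (0.10 log units; within the scatter), a change that may well stay within the scatter. Compound 4 is therefore estimated at 8000 nM, with a range from 2500 nM to 25000 nM.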

Compound 4, inhibition constant: 16200 nM
The estimate for compound 4 lay 2.0-fold (0.31 log units) below the measured number; measured number inside the range.
By their numbers in this assay, from the lowest: compound 1; then compounds 2 and 4 (each within the scatter of the next).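

For the compounds shown here, at the saturated chain carbon bound to an amide-type nitrogen and a carbonyl carbon, isopropyl in place of 2-(methylsulfanyl)ethyl gives a 1.6-fold higher number from compound 2 to compound 4 (0.21 log units; within the scatter), the first single change that can be read here. In this assay, this swap therefore leaves the two groups indistinguishable, even though one carries sulfur and the other does not. Repeat entries for a single compound also spread visibly: the several entries of compound 3 in this assay, 5100 nM; 3900 nM (2 entries). On these data alone, whether an amine or a carboxylic acid at this place would move the number beyond the scatter remains open.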